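The source may hold more compounds than are shown below. What is called first, only, known or untested is meant among the compounds shown, and "the series" means these compounds.

Measured so far in an assay on CHO cells for displacement of a labelled ligand from adenosine receptor A1 (Homo sapiens); on this read-out higher numbers stand for weaker inhibition and lower numbers for stronger inhibition:

Compound 1 `COc1ccc(-c2c(C#N)c(N)nc(SCc3nc(-c4ccc(Cl)cc4)sc3Cl)c2C#N)cc1` gives 88 nM.
Compound 2 `COc1ccc(-c2c(C#N)c(N)nc(SCc3csc(-c4ccc(Br)cn4)n3)c2C#N)cc1` gives 53 nM.

Compound 2 and compound 1 differ in the ring that carries the halogen and in the halogen itself, and their two numbers sit within the usual scatter of each other, so neither stands apart in this assay. Compound 3 `COc1ccc(-c2c(C#N)c(N)nc(SCc3csc(-c4ccc(Cl)cn4)n3)c2C#N)cc1` is compound 2 with chloro in place of bromo on an aromatic carbon. For the measured compounds named here, no measured pair shows this exact swap, and a bromo-to-chloro exchange is small, so the step from compound 2 to compound 3 is expected to be a 1.1-fold higher number from compound 2 to compound 3 (0.05 log units; within the scatter), nothing beyond the scatter in either direction. Compound 3 is therefore estimated at 60 nM, with a range from 25 nM to 150 nM.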

Compound 3, inhibition constant: 24 nM
For compound 3 the middle estimate is 2.5-fold (0.40 log units) above the measured one; the measured number lies below the stated range.
By their numbers in this assay, from the lowest: compound 3; then compounds 2 and 1 (each within the scatter of the next).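

In this assay, the change from 5-bromopyridin-2-yl to 5-chloropyridin-2-yl gives a 2.2-fold lower number from compound 2 to compound 3 (0.34 log units; beyond the scatter). For the compounds shown here, this is the first comparison here in which only one place differs, and it shows that the read-out responds to the choice of halogen on this aromatic carbon, although the step is modest. No available measurement explains why the number falls with chloro. The compounds shown leave open how fluoro, methyl or an amine at this place would read, and whether the same exchange would give a similar step elsewhere on the molecule.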